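Shortening the Chain That Carries the Hydroxycarbamoyl Group

The source may hold more compounds than are shown below. What is called first, only, known or untested is meant among the compounds shown, and "the series" means these compounds.

Of the compounds shown here, three have been tested in a functional assay on HCT-116 cells (Homo sapiens) for inhibition, read by MTT assay, with a stated time of 72 h; on this read-out lower numbers stand for stronger inhibition and higher numbers for weaker inhibition. Among the compounds with values here, compound 1 `CNC(=O)CCCCCCCn1nc(-c2ccc3oc(N)nc3c2)c2c(N)ncnc21` gives 3150 nM, and compound 3 `Nc1nc2cc(-c3nn(CCCCCCC(=O)NO)c4ncnc(N)c34)ccc2o1` gives 5390 nM; the one paired step between them, a 1.7-fold higher number from compound 1 to compound 3 (0.23 log units; within the scatter), lies within the scatter. Compound 2 `Nc1ncnc2c1c(-c1cnc3[nH]ccc3c1)nn2CCCCCC(=O)NO` gives 63700 nM, the highest number of the three and beyond the scatter from both others. Compound 4 `Nc1ncnc2c1c(-c1cnc3[nH]ccc3c1)nn2CCC(=O)NO` differs from compound 2 by hydroxycarbamoyl in place of 3-(hydroxycarbamoyl)propyl on a saturated chain carbon, two bonds along the chain from an aromatic nitrogen. Within the data shown here, no measured pair shows a shortening of this chain, so no step speaks to it directly; the single measured step concerns a different end group on a chain of unchanged length. Without such a guide, the step is expected to be a 1.3-fold higher number from compound 2 to compound 4 (0.10 log units; within the scatter), with the direction uncertain. Compound 4 is therefore estimated at 80000 nM, within 25000 nM to 250000 nM.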

Compound 4, half-maximal inhibitory concentration: > 150000 nM
Compound 4 gave a limit, no number (the forecaster's own chance of this, stated with the estimate: 25%); at least 1.8-fold (0.27 log units) between middle value and limit.
By their numbers in this assay, from the lowest: compounds 1 and 3 (each within the scatter of the next); then compound 2. At a limit, above all of these: compound 4.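

Compound 4 gives only a limit in this assay, > 150000 nM, and not a number. Cutting the chain at this position, with hydroxycarbamoyl in place of 3-(hydroxycarbamoyl)propyl, gives an at least 2.3-fold higher number from compound 2 to compound 4 (0.37 log units; beyond the scatter), so this is the first step here to show that shortening the chain raises the number beyond the scatter. How far the number rises cannot be read, and the step marks only a lower bound: the limit of > 150000 nM in this assay, at which 1 of the 4 values shown sits.

Going by these compounds, whether a longer chain on the core of compound 2 would lower the number remains open. So does how a carboxylic acid would read in place of the hydroxycarbamoyl group on the short chain of compound 4.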